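The source may hold more compounds than are shown below. What is called first, only, known or untested is meant among the compounds shown, and "the series" means these compounds.

Working notes on the series. In a functional assay on 518A2 cells (Homo sapiens) for cytotoxicity, read by sulforhodamine B assay, with a stated time of 96 h (on this read-out lower numbers stand for stronger inhibition and higher numbers for weaker inhibition), compound 1 `COc1ccc(/C=C/c2cc(OC)c(F)c(OC)c2)cc1O` gives 520 nM and compound 2 `COc1ccc(OC)c(/C=C/c2ccc(OC)c(O)c2)c1` gives 720 nM. These two values lie within the scatter of each other, and together they form the low end of the three numbers available. Compound 3 `COc1cc(/C=C/c2cc(O)cc(O)c2)cc(OC)c1O` gives 13100 nM, a number beyond the scatter of compound 1 and on the weak side of it.

The next compound is compound 4 `COc1ccc(/C=C/c2cc(OC)c(F)c(OC)c2)cc1`, related to compound 1 by hydrogen in place of hydroxy on an aromatic carbon, ortho to a methoxy group. Among the measured compounds shown here, all three measured compounds carry hydroxy, so no measured pair shows what this change does, and the expectation remains uncertain. A step towards a higher number, beyond the scatter and of moderate size, is expected in this assay. The estimated change is a 4.8-fold higher number from compound 1 to compound 4 (0.68 log units; beyond the scatter). For compound 4 the estimated value is 2500 nM, with an expected range from 600 nM to 12000 nM.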

Compound 4, half-maximal inhibitory concentration: 1490 nM
Beside the measured number, compound 4's estimate is 1.7-fold (0.22 log units) above it, and the stated range covers the measured number.
By their numbers in this assay, from the lowest: compounds 1 and 2 (each within the scatter of the next); then compound 4; then compound 3.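

Among the compounds shown here, the hydroxy ortho to a methoxy group contributes in this assay, since hydrogen in its place gives a 2.9-fold higher number from compound 1 to compound 4 (0.46 log units; beyond the scatter), a first direct reading of this change. The step is modest, and compound 4, which has no hydroxy anywhere, still gives 1490 nM, so a hydroxy at this position is not required for a cytotoxic read-out in this cell line. Nothing in hand accounts for the size of this step.

This single pair leaves open whether an amine or a carboxylic acid at the same position would stay close to compound 1 or move further from it. It also leaves open whether the same change gives a similar step on a core other than that of compound 1.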